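Piperazine nitrogen substituents and tolerated concentration

The source may report more compounds than this note shows. Statements on the series, on what has been measured and on what is new or still open speak of the compounds shown alone.

Compound 3 `CCOC(=O)N1CCN(/N=N/c2ccccc2)CC1` gives 100000 nM in an ADME assay on MT4 cells (Homo sapiens) for cytotoxicity, read by MTT assay, with a stated time of 96 h (a lower number here means that less compound is tolerated, a higher number that more compound is tolerated), and holds the highest of the two numbers in the set. Its nearest neighbour, compound 2 `c1ccc(/N=N/N2CCN(c3ccccc3)CC2)cc1`, gives 33000 nM. Compound 1 `c1ccc(/N=N/N2CCCC2)cc1` gives only a limit, > 100000 nM, in this assay. One of the three values sits at the limit of > 100000 nM in this assay, at which 1 of the 3 values shown sits. Among the measured compounds shown here, the single measured step, a 3.0-fold higher number from compound 2 to compound 3 (0.48 log units; beyond the scatter), raises the number. Compound 4 `c1ccc(/N=N/N2CCN(c3ncccn3)CC2)cc1` differs from compound 3 by pyrimidin-2-yl in place of ethoxycarbonyl on an amine nitrogen in a ring. The pyrimidin-2-yl ring is closer in kind to the phenyl of compound 2 than to the ethoxycarbonyl of compound 3. A modest fall is therefore expected for compound 4, a 2.0-fold lower number from compound 3 to compound 4 (0.30 log units; within the scatter), within or just beyond the scatter. Compound 4 is estimated at 50000 nM, with a range of 20000 nM to 110000 nM.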

Compound 4, half-maximal cytotoxic concentration: 90000 nM
For compound 4 the middle estimate is 1.8-fold (0.26 log units) below the measured one; low and high end bracket the measured number.
By their numbers in this assay, from the lowest: compound 2; then compounds 4 and 3 (each within the scatter of the next).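

On the amine nitrogen in the ring, an aromatic ring alone does not bring the lower number. With a 1.1-fold lower number from compound 3 to compound 4 (0.05 log units; within the scatter), pyrimidin-2-yl and ethoxycarbonyl cannot be told apart in this assay, whereas a 2.7-fold higher number from compound 2 to compound 4 (0.44 log units; beyond the scatter) separates pyrimidin-2-yl from phenyl. Among the groups shown on this nitrogen, the lower number therefore stays with the phenyl of compound 2, and one value in the set is a limit and not a number: the limit of > 100000 nM in this assay, at which 1 of the 4 values shown sits.

Still open, going by these compounds, is whether an amine, a carboxylic acid or a longer chain on this nitrogen would stay with compound 3 and compound 4 or join compound 2.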